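The source may hold more compounds than are shown below. What is called first, only, known or untested is meant among the compounds shown, and "the series" means these compounds.

Measured compounds:
- compound 1, `COc1cccc(C#Cc2ccccc2C#CCCCCO)c1`: 1800 nM
- compound 2, `OCCCCC#Cc1ccccc1C#Cc1cccc(O)c1`: 19200 nM

Of the compounds shown here, two have been measured in a functional assay on K562 cells (Homo sapiens) for cytotoxicity; a lower number here means a stronger inhibitor of growth, a higher number a weaker inhibitor of growth. Compound 1, `COc1cccc(C#Cc2ccccc2C#CCCCCO)c1`, gives 1800 nM in this assay. Within the data shown here, compound 2, `OCCCCC#Cc1ccccc1C#Cc1cccc(O)c1`, gives 19200 nM, the higher of the two numbers; its nearest neighbour is compound 1, and the only measured step, an 11-fold higher number from compound 1 to compound 2 (1.03 log units; beyond the scatter), is large and beyond the scatter.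

Compound 3, `OCCCCC#Cc1ccccc1C#Cc1cccc(C(F)(F)F)c1`, has not yet been measured. It differs from compound 2 by trifluoromethyl in place of hydroxy on an aromatic carbon. Among the measured compounds shown here, the one step that bears on this change is the exchange of hydroxy for methyl on the same oxygen, an 11-fold higher number from compound 1 to compound 2 (1.03 log units; beyond the scatter), which raised the number markedly. The new change again takes away the hydroxy, and with it a hydrogen-bond donor and acceptor, so a step back toward the lower number of compound 1 is expected, though the trifluoromethyl is not the methoxy of compound 1 and the size is uncertain. The expected step is a 5.5-fold lower number from compound 2 to compound 3 (0.74 log units; beyond the scatter). For compound 3 the estimate in this assay is 3500 nM, with a range from 900 nM to 14000 nM.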

Compound 3, concentration for 50% growth inhibition: 22500 nM
Beside the measured number, compound 3's estimate is 6.4-fold (0.81 log units) below it; the measured number lies above the stated range.
By their numbers in this assay, from the lowest: compound 1; then compounds 2 and 3 (each within the scatter of the next).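

In this assay the exchange of hydroxy for trifluoromethyl gives a 1.2-fold higher number from compound 2 to compound 3 (0.07 log units; within the scatter) and the two compounds cannot be told apart, although trifluoromethyl has 0 hydrogen-bond donors and 0 hydrogen-bond acceptors where hydroxy has 1 of each. Taking away the hydroxy is therefore not enough on its own to reach the lower number of compound 1, since the exchange of methoxy for trifluoromethyl gives a 13-fold higher number from compound 1 to compound 3 (1.10 log units; beyond the scatter) and that step is large. Of the three groups seen at this position, only methoxy goes with the lower number, so the earlier step now reads as something particular to methoxy and not as a penalty carried by hydroxy alone.

From the compounds shown here alone, whether the oxygen of methoxy, its methyl or the two together make the difference stays open, and a plain methyl, an ethoxy group or an amine at this position would be needed to separate these readings. The compounds shown also give no measured reason why methoxy stands apart from hydroxy and trifluoromethyl.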